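3,4-Dimethoxyphenyl in place of 4-hydroxyphenyl: working notes

A few compounds are considered here, and "the series" means these few. Any claim that something is new, unique, unknown or untested is made for them only; others in the source may bear on it.

In a functional assay on KB cells (Homo sapiens) for inhibition, read by sulforhodamine B assay (on this read-out lower numbers stand for stronger inhibition of growth and higher numbers for weaker inhibition of growth), compound 3 `Oc1ccc(-c2ccc(-c3ccc(-c4nc5ccccc5[nH]4)cc3)cc2)cc1` gives 41000 nM and compound 2 `FC(F)(F)c1ccc(-c2ccc(-c3ccc(-c4nc5ccccc5[nH]4)cc3)cc2)cc1` gives 47200 nM. Among the compounds with values here, these two sit together at the high end of the numbers so far, with a 1.2-fold lower number from compound 2 to compound 3 (0.06 log units; within the scatter). Compound 1 `COc1ccc(-c2ccc(-c3ccc(-c4nc5cc(C)ccc5[nH]4)cc3)cc2)cc1OC` stands well apart from both at 2190 nM, the lowest of the three numbers.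

The step under consideration leads to compound 4 `COc1ccc(-c2ccc(-c3ccc(-c4nc5ccccc5[nH]4)cc3)cc2)cc1OC`: 3,4-dimethoxyphenyl in place of 4-hydroxyphenyl on an aromatic carbon. Within the data shown here, the change is 3,4-dimethoxyphenyl in place of 4-hydroxyphenyl, at the same place on the shared core as the one measured step. That step, hydroxy in place of trifluoromethyl, gave a 1.2-fold lower number from compound 2 to compound 3 (0.06 log units; within the scatter), so it offers no sign of how far a change at this place can move the number. The better guide is compound 1, which carries the same 3,4-dimethoxyphenyl as compound 4 and differs from it only by an extra methyl on the core. No measurement separates the effect of that methyl, so the gap between compound 3 and compound 1 is only an approximate guide.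

A clear fall in this assay is therefore expected, landing near compound 1 at 2190 nM. The estimated step is a 14-fold lower number from compound 3 to compound 4 (1.14 log units; beyond the scatter), toward stronger inhibition of growth. For compound 4 the expected value is 3000 nM, with an estimated range of 1000 nM to 12000 nM.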

Compound 4, concentration for 50% growth inhibition: 9250 nM
For compound 4 the middle estimate is 3.1-fold (0.49 log units) below the measured one; measured number inside the range.
By their numbers in this assay, from the lowest: compound 1; then compound 4; then compounds 3 and 2 (each within the scatter of the next).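

In this assay, within the data shown here, 3,4-dimethoxyphenyl is the first group at this place to move the number beyond the scatter: the change gives a 4.4-fold lower number from compound 3 to compound 4 (0.65 log units; beyond the scatter) against 4-hydroxyphenyl and a 5.1-fold lower number from compound 2 to compound 4 (0.71 log units; beyond the scatter) against 4-(trifluoromethyl)phenyl, while the earlier step of a 1.2-fold lower number from compound 2 to compound 3 (0.06 log units; within the scatter) showed no separation between those two groups. The methyl on the core also matters in the presence of 3,4-dimethoxyphenyl, since hydrogen in its place gives a 4.2-fold higher number from compound 1 to compound 4 (0.63 log units; beyond the scatter) and so 3,4-dimethoxyphenyl alone does not reach the number of compound 1 on this core. No measurement available here accounts for either step, and the numbers alone must stand without explanation.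

Going by these compounds, it remains open whether a single methoxy group at this place would match the pair in compound 4, and whether a quite different group such as an amine or a carboxylic acid on the same aromatic ring would move the number further in either direction. On these data alone, it is also open whether the methyl on the core gives a step of similar size when 4-hydroxyphenyl or 4-(trifluoromethyl)phenyl occupies this place, as only the 3,4-dimethoxyphenyl pair tests it so far.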